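Aryl versus cyclopropyl on the ring amide nitrogen

The source may report more compounds than this note shows. Statements on the series, on what has been measured and on what is new or still open speak of the compounds shown alone.

Measured so far:
Compound 1 `COc1ncc(-c2ccc3c(c2)N(c2ccc(C)cc2)C(=O)CO3)cc1NS(=O)(=O)c1ccc(F)cc1` — 12900 nM
Compound 2 `COc1ncc(-c2ccc3c(c2)N(c2ccc(Cl)cc2)C(=O)CO3)cc1NS(=O)(=O)c1ccc(F)cc1` — 24100 nM
Compound 3 `COc1ncc(-c2ccc3c(c2)N(C2CC2)C(=O)CO3)cc1NS(=O)(=O)c1ccc(F)cc1` — 23900 nM

These three compounds share one core and differ only in the group carried on the amide-type nitrogen in the ring. In a functional assay on A-375 cells (Homo sapiens) for antiproliferative activity, read by MTT assay, with a stated time of 72 h (on this read-out lower numbers stand for stronger inhibition and higher numbers for weaker inhibition), compound 3 gives 23900 nM, the second highest of the three numbers; its nearest neighbour is compound 2 a 1.0-fold lower number from compound 2 to compound 3 (0.00 log units; within the scatter), and its furthest is compound 1 a 1.9-fold higher number from compound 1 to compound 3 (0.27 log units; within the scatter). Both of those steps fall within the scatter, so the three values cannot be told apart.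

Compound 4 `COc1cccc(N2C(=O)COc3ccc(-c4cnc(OC)c(NS(=O)(=O)c5ccc(F)cc5)c4)cc32)c1` is not yet measured. It differs from compound 3 in one place: 3-methoxyphenyl in place of cyclopropyl on an amide-type nitrogen in a ring. Within the data shown here, the steps that bear on this change are the two in which an aryl group stands in place of cyclopropyl on that same nitrogen, a 1.9-fold higher number from compound 1 to compound 3 (0.27 log units; within the scatter) and a 1.0-fold lower number from compound 2 to compound 3 (0.00 log units; within the scatter), and neither rose above the scatter. A third aryl group at the same place is therefore expected to give much the same number, with no step beyond the scatter in this assay in either direction, a 1.4-fold lower number from compound 3 to compound 4 (0.15 log units; within the scatter). Compound 4 is thus estimated at 17000 nM, with a range from 7000 nM to 40000 nM.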

Compound 4, half-maximal inhibitory concentration: > 40000 nM
Compound 4 ended at the assay's limit; the forecaster's own chance of this, stated with the estimate: 10%; at least 2.3-fold (0.37 log units) between middle value and limit.
By their numbers in this assay, from the lowest: compounds 1, 3 and 2 (each within the scatter of the next). At a limit, above all of these: compound 4.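

In this assay compound 4 stands at a limit of the assay and not at a number: the limit of > 40000 nM in this assay, at which 1 of the 4 values shown sits. Among these compounds, with 3-methoxyphenyl in place of 4-methylphenyl on the amide-type nitrogen, the result is an at least 3.1-fold higher number from compound 1 to compound 4 (0.49 log units; beyond the scatter), the first step at this position to pass the scatter, so the aryl groups here are not all alike. The other two floors, an at least 1.6-fold higher number from compound 3 to compound 4 (0.22 log units; that floor lies within the scatter) and an at least 1.6-fold higher number from compound 2 to compound 4 (0.22 log units; that floor lies within the scatter), lie within the scatter, so these values do not set compound 4 apart from compound 3 or compound 2.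

From the compounds shown here alone, it remains open whether an unsubstituted phenyl group, or a phenyl group carrying an amine or a carboxylic acid, would read like compound 1 or like compound 4. Going by these compounds, how a longer alkyl chain on this nitrogen would read is also open.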